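Sulfonamide nitrogen substitution in the anilide series

This account rests on a few compounds, and the source may have more. Where it says the series, first, only, none or still open, it means among the compounds named here.

Measured so far:
compound 1 `CN(c1ccccc1)S(=O)(=O)c1ccc(NC(=O)c2ccc(Cl)cc2Cl)cc1`: 2570 nM
compound 2 `O=C(Nc1ccc(S(=O)(=O)Nc2ccccc2)cc1)c1ccc(I)cc1F`: 5130 nM
compound 3 `Cc1cc(Br)ccc1C(=O)Nc1ccc(S(=O)(=O)Nc2ccccc2)cc1`: 851 nM

In a functional assay on HEK293 cells for agonist activity at probable G-protein coupled receptor 27 (Homo sapiens), read by a luciferase reporter and beta-arrestin recruitment, with a stated time of 10 min (a higher number here means that more compound is needed for the effect, a lower number that less compound is needed), compound 1 gives the second highest of the three numbers. Compound 2 sits within the scatter of it, so the two cannot be ordered; compound 3 lies beyond the scatter on the lower side, with a lower number than compound 1.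

For the measured compounds named here, the only single-point step measured is a 6.0-fold lower number from compound 2 to compound 3 (0.78 log units; beyond the scatter), and it concerns the group on the carbonyl carbon, which is not what changes here.

Compound 4 `O=C(Nc1ccc(S(=O)(=O)Nc2ccccc2Cl)cc1)c1ccc(Cl)cc1Cl` differs from compound 1 as follows: (2-chlorophenyl)amino in place of methyl(phenyl)amino on a sulfonyl sulfur. Going by the values given here, no measured pair isolates this change. Compounds 2 and 3 carry phenylamino on the sulfonyl sulfur, but each also differs from compound 1 on the carbonyl carbon, so they give no clean reading of the nitrogen substituent. Their values merely bracket compound 1 on both sides.

With nothing to push in either direction, the expected step of a 1.3-fold lower number from compound 1 to compound 4 (0.11 log units; within the scatter) is none beyond the scatter, and compound 4 is estimated at 2000 nM, between 500 nM and 8000 nM.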

Compound 4, half-maximal effective concentration: 1260 nM
For compound 4 the middle estimate is 1.6-fold (0.20 log units) above the measured one; the range from low to high includes it.
By their numbers in this assay, from the lowest: compounds 3 and 4 (each within the scatter of the next); then compounds 1 and 2 (each within the scatter of the next).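

In this assay, for the compounds shown here, a 2.0-fold lower number from compound 1 to compound 4 (0.31 log units; beyond the scatter) gives the first reading at the sulfonyl sulfur with the group on the carbonyl carbon held constant, and the change lies just beyond the scatter. The exchange of methyl(phenyl)amino for (2-chlorophenyl)amino leaves the heavy-atom count unchanged and adds one hydrogen-bond donor, but it removes the methyl and introduces the chlorine in a single step, so the two alterations cannot be read apart. Nothing at hand gives a cause for this step.

Still open, on these data alone, is which alteration carries the step: (2-chlorophenyl)(methyl)amino or plain phenylamino on the sulfonyl sulfur, paired with the carbonyl group of compound 1, would separate them. Also open, as far as these compounds go, is how other groups read here, such as cyclohexylamino or (2-methoxyphenyl)amino.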